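From 4-fluoro-3-methylphenyl to 4-fluorophenyl

A few compounds are considered here, and "the series" means these few. Any claim that something is new, unique, unknown or untested is made for them only; others in the source may bear on it.

In a functional assay on NCI-H520 cells (Homo sapiens) for cytotoxicity (a lower number here means a stronger inhibitor of growth, a higher number a weaker inhibitor of growth), compound 1 (`COc1ccc(C2=C(c3ccc(SC)cc3)CC3CCCN3C2=O)cc1OC(=O)CNC(=O)OC(C)(C)C`) gives 7000 nM and compound 2 (`CSc1ccc(C2=C(c3ccc(F)c(C)c3)C(=O)N3CCCC3C2)cc1`) gives 500 nM, the lower of the two numbers and beyond the scatter from compound 1. Compound 3 (`CSc1ccc(C2=C(c3ccc(F)cc3)C(=O)N3CCCC3C2)cc1`) differs from compound 2 by hydrogen in place of methyl on an aromatic carbon, ortho to a fluoro group: hydrogen in place of methyl on an aromatic carbon. Going by the values given here, no measured pair shows this change, so the expectation rests on its small size alone. The expected step is none beyond the scatter, with a slight rise at most: a 1.4-fold higher number from compound 2 to compound 3 (0.15 log units; within the scatter). For compound 3 the estimated value is 700 nM, with an expected range of 250 nM to 2000 nM.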

Compound 3, concentration for 50% growth inhibition: 250 nM
The estimate for compound 3 lay 2.8-fold (0.45 log units) above the measured number; the range from low to high includes it.
By their numbers in this assay, from the lowest: compounds 3 and 2 (each within the scatter of the next); then compound 1.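

In this assay hydrogen in place of methyl on this aromatic carbon gives a 2.0-fold lower number from compound 2 to compound 3 (0.30 log units; within the scatter) and so no change beyond the scatter. The methyl ortho to a fluoro group is therefore not required to hold the level of compound 2 in this series. Nothing measured gives a reason for this result.

The compounds shown carry only hydrogen or methyl at this carbon, so a larger or charged group, such as methoxy, an amine or a carboxylic acid, remains untested there. On these data alone, the contribution of the fluoro group also remains open.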